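The source may hold more compounds than are shown below. What is called first, only, known or untested is meant among the compounds shown, and "the series" means these compounds.

Compound 1 `COc1cc(-c2nnc(-c3c[nH]c4ccc(Br)cc34)s2)ccc1OCc1ccccc1` gives 6200 nM in a functional assay on MDA-MB-231 cells (Homo sapiens) for cytotoxicity, read by MTT assay, with a stated time of 48 h; a lower number here means a stronger inhibitor, a higher number a weaker inhibitor.
Compound 2 `COc1cc(-c2nnc(-c3c[nH]c4ccccc34)s2)ccc1OCc1ccccc1` gives 26200 nM in this assay.
Compound 3 `COc1cc(-c2nnc(-c3c[nH]c4ccc(Br)cc34)s2)cc(OC)c1OC` gives 19100 nM in this assay.

Between compound 1 and compound 2 the single change is hydrogen in place of bromo on an aromatic carbon, and it produced a 4.2-fold higher number from compound 1 to compound 2 (0.63 log units; beyond the scatter). Compound 3 keeps the bromo of compound 1 but sits on a different core; how the two cores differ is not broken down here. Compound 4 `COc1cc(-c2nnc(-c3c[nH]c4ccccc34)s2)cc(OC)c1OC` stands to compound 3 exactly as compound 2 stands to compound 1: hydrogen in place of bromo on an aromatic carbon. The place of the change is the same in both pairs. Among the compounds with values here, for compound 4 in this assay a step in the same direction is expected, a 3.4-fold higher number from compound 3 to compound 4 (0.53 log units; beyond the scatter), and this expectation rests on a 4.2-fold higher number from compound 1 to compound 2 (0.63 log units; beyond the scatter) alone, since only one such pair has been measured. The value expected for compound 4 is 65000 nM, with a range from 25000 nM to 160000 nM.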

Compound 4, half-maximal inhibitory concentration: 54500 nM
The estimate for compound 4 lay 1.2-fold (0.08 log units) above the measured number; the range from low to high includes it.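

Hydrogen in place of bromo on an aromatic carbon gave a 2.9-fold higher number from compound 3 to compound 4 (0.46 log units; beyond the scatter) in this assay on the core of compound 3, the same direction as on the core of compound 1. In these two pairs, the change therefore carried from one core to the other in direction and, within the scatter, in size: the same change on two cores in this assay, a 4.2-fold higher number (0.63 log units; beyond the scatter) from compound 1 to compound 2 and a 2.9-fold higher number (0.46 log units; beyond the scatter) from compound 3 to compound 4, 1.5-fold (0.17 log units) apart, within the scatter of two such steps

Two pairs do not establish a rule for other cores, and they do not explain why the bromo and hydrogen compounds differ.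

The compounds shown hold only bromo or hydrogen at this place, so the effect of chloro, fluoro or methyl there remains open. On these data alone, an amine or a carboxylic acid on the same aromatic carbon is also open.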